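The source may report more compounds than this note shows. Statements on the series, on what has been measured and on what is new or still open speak of the compounds shown alone.

Measured compounds:
- compound 1, `O=C(O)c1ccccc1-c1ccc(CCc2ncc(Cc3ccccc3F)[nH]2)cc1`, 9.5 nM
- compound 2, `O=C(O)c1ccccc1-c1ccc(CCc2ncc(Cc3ccc(Cl)cc3)[nH]2)cc1`, 102 nM

Compound 2 stands at the higher of the two numbers recorded in an in vitro functional assay on cells for agonist activity at Bombesin receptor subtype-3 (Mus musculus), read by luminescence and calcium flux (on this read-out lower numbers stand for an effect already at smaller amounts and higher numbers for an effect only at larger amounts of compound), and its nearest neighbour is compound 1, which lies an 11-fold higher number from compound 1 to compound 2 (1.03 log units; beyond the scatter) below it. That one step, the only one measured, exchanges one aryl group for another on the same chain carbon and is large and beyond the scatter.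

Compound 3, `O=C(O)c1ccccc1-c1ccc(CCc2ncc(CCc3ccccc3)[nH]2)cc1`, has not yet been measured in this assay. It differs from compound 2 by benzyl in place of 4-chlorophenyl on a saturated chain carbon bound to an aromatic carbon. Within the data shown here, no measured step bears directly on this change: the step from compound 1 to compound 2 compares two different halogenated aryl groups, whereas here the chlorine leaves and the chain between the imidazole and the phenyl ring grows by one carbon. The aryl change is of the same kind that moved the number strongly before, but nothing shows which way it will move now. Compound 3 is therefore expected to give 60 nM in this assay, within a wide range from 12 nM to 300 nM, which is a step of a 1.7-fold lower number from compound 2 to compound 3 (0.23 log units; within the scatter) expected from compound 2.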

Compound 3, half-maximal effective concentration: 174 nM
Compound 3: the middle estimate sits 2.9-fold (0.46 log units) below what was measured; the measured number falls inside the stated range.
By their numbers in this assay, from the lowest: compound 1; then compounds 2 and 3 (each within the scatter of the next).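

In this assay, the exchange of 4-chlorophenyl for benzyl on a saturated chain carbon bound to an aromatic carbon, which also reads as 4-chlorobenzyl to phenethyl, gives a 1.7-fold higher number from compound 2 to compound 3 (0.23 log units; within the scatter), so these two different groups are not separated at this position. The exchange of 2-fluorophenyl for benzyl at the same place gives an 18-fold higher number from compound 1 to compound 3 (1.26 log units; beyond the scatter), so compound 1 now stands apart from both other compounds, and the large step seen earlier is no longer tied to the 4-chlorophenyl group alone. Nothing available explains why the 2-fluorophenyl group stands apart here.

The compounds shown leave open how much of the step to compound 3 belongs to the loss of the halogen and how much to the longer chain, since the two differences arrive together; an unsubstituted phenyl, a 4-fluorophenyl or a 2-chlorophenyl group at this place would begin to separate them. They also leave open whether the low number of compound 1 would persist with a 2-fluorobenzyl group, which carries the same halogen on the longer chain.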